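Naphthyl Carbinol Series: Fluorophenyl in Place of Pyridinyl

The source may hold more compounds than are shown below. What is called first, only, known or untested is meant among the compounds shown, and "the series" means these compounds.

The compounds share an amino-alcohol skeleton. Compound 1 `COc1nc(-c2ccncc2)ccc1[C@@H](c1ccccc1)[C@@](O)(CCN(C)C)c1cccc2ccccc12` carries a pyridin-4-yl group on its core. In a toxicity assay on Vero cells (Chlorocebus sabaeus) for cytotoxicity (a lower number here means that less compound is tolerated, a higher number that more compound is tolerated), compound 1 gives only a limit of the assay, > 50 ug/mL. Compound 2 `COc1ncc(-c2ccccc2)cc1[C@@H](c1ccccc1)[C@@](O)(CCN(C)C)c1ccccc1` likewise reaches only the limit > 50 ug/mL in this assay. Compound 3 `COc1ncc(-c2ccccc2)cc1[C@@H](c1ccccc1)[C@@](O)(CCN(C)C)c1cccc(F)c1F` differs from compound 2 by a 2,3-difluorophenyl in place of phenyl on a saturated chain carbon bound to an oxygen on a saturated carbon and two saturated chain carbons. Compound 3 also stops at the limit > 50 ug/mL. The step that the two limits leave unreadable from compound 2 to compound 3 therefore cannot be read, and the limit of > 50 ug/mL in this assay, at which 3 of the 3 values shown sit, is all that is known about this group. Compound 4 `COc1nc(-c2cccc(F)c2)ccc1[C@@H](c1ccccc1)[C@@](O)(CCN(C)C)c1cccc2ccccc12` differs from compound 1 by 3-fluorophenyl in place of pyridin-4-yl on an aromatic carbon. Going by the values given here, no measured step bears on this change, and every measured value sits at the limit. For compound 4 the step that the limit leaves unreadable from compound 1 to compound 4 is expected to stay within the scatter. Compound 4 is expected to give about 60 ug/mL, between 30 ug/mL and 120 ug/mL, most likely once more reported only as a limit.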

Compound 4, half-maximal cytotoxic concentration: > 50 ug/mL
Compound 4: only a limit was reported; the forecaster's own chance of this, stated with the estimate: 85%; the middle value lies beyond the limit too.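

Compound 1 and compound 4 both stop at a limit in this assay, so no step between them can be read: the limit of > 50 ug/mL in this assay, at which 4 of the 4 values shown sit.

The compounds shown leave open where the true value of any of them lies, and whether 3-fluorophenyl in place of pyridin-4-yl changes it at all.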